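The compounds below may be only part of what the source reports. "The series", "measured", "known", "first", "only" and "open" are said of these compounds alone.

Measured compounds:
compound 1 `CCC1(OC(=O)N2CCC(Oc3ncnc(Oc4ccc(S(C)(=O)=O)nc4C)c3F)CC2)CC1`, 22 nM
compound 2 `Cc1nc(S(C)(=O)=O)ccc1Oc1ncnc(OC2CCN(C(=O)SC(C)(C)C)CC2)c1F`, 4.83 nM

Going by the values given here, compound 2 stands lowest of the two in a functional assay on isolated protein for inhibition of Glucose-dependent insulinotropic receptor (Homo sapiens), read by HTRF and cAMP accumulation (on this read-out lower numbers stand for an effect already at smaller amounts and higher numbers for an effect only at larger amounts of compound), and compound 1 gives the only comparison. Among the compounds with values here, the single measured step, a 4.6-fold lower number from compound 1 to compound 2 (0.66 log units; beyond the scatter), changed the group on the same carbonyl carbon that compound 3 `Cc1nc(S(C)(=O)=O)ccc1Oc1ncnc(OC2CCN(C(=O)c3nc(C(C)(C)F)no3)CC2)c1F` alters. Compound 3 differs from compound 2 by a group of 9 heavy atoms (5 carbon, 2 nitrogen, 1 oxygen, 1 fluorine; one five-membered aromatic ring with 3 hetero atoms) in place of a group of 5 heavy atoms (4 carbon, 1 sulfur; no ring), on a carbonyl carbon. Within the data shown here, no measured compound carries an aromatic ring at this carbonyl carbon, so the direction of the step is uncertain; since the one known change there was modest, the expected step of a 1.4-fold higher number from compound 2 to compound 3 (0.16 log units; within the scatter) is likewise small. Compound 3 is estimated at 7 nM, within a range of 2 nM to 25 nM.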

Compound 3, half-maximal effective concentration: 43.4 nM
Beside the measured number, compound 3's estimate is 6.2-fold (0.79 log units) below it, and the stated range ends below it.
By their numbers in this assay, from the lowest: compound 2; then compounds 1 and 3 (each within the scatter of the next).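

Placing the five-membered aromatic ring on the carbonyl carbon in place of (tert-butyl)sulfanyl gives a 9.0-fold higher number from compound 2 to compound 3 (0.95 log units; beyond the scatter) in this assay, so this position also tolerates change less well in the upward direction than the earlier step suggested. Against the group of compound 1, the same ring gives a 2.0-fold higher number from compound 1 to compound 3 (0.30 log units; within the scatter), which lies within the scatter, so those two groups cannot be told apart here. Nothing available explains either result. Going by these compounds, it remains open how a phenyl ring or a dimethylamino group on this carbonyl carbon would read, and whether the step to compound 3 follows from the aromatic ring itself or from the fluorine-bearing substituent on it.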